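Swapping Vinyl for Chloromethyl on the Amide Carbonyl

A few compounds are considered here, and "the series" means these few. Any claim that something is new, unique, unknown or untested is made for them only; others in the source may bear on it.

Of the compounds shown here, two have been measured in a functional assay on Z-138 cells (Homo sapiens) for inhibition, read by luminescence and CellTiter-Glo, with a stated time of 72 h; on this read-out higher numbers stand for weaker inhibition and lower numbers for stronger inhibition. Compound 1 `O=C(CCl)Nc1cccc(Cn2nc(-c3ccc(Oc4ccccc4)cc3)cc2CO)c1` gives 400 nM, and compound 2 `C=CC(=O)Nc1cccc(Cn2nc(-c3ccc(Oc4ccccc4)cc3)cc2C(=O)OCC)c1` gives 7800 nM, the higher of the two numbers by a margin beyond the scatter. Among the compounds with values here, no single-point step links them, as the two differ in more than one place. Compound 3 `CCOC(=O)c1cc(-c2ccc(Oc3ccccc3)cc2)nn1Cc1cccc(NC(=O)CCl)c1` is formed from compound 2 by one change: chloromethyl in place of vinyl on a carbonyl carbon. Because compound 1, which gives 400 nM, carries the entering group, the author expects a step towards a lower number, a 3.9-fold lower number from compound 2 to compound 3 (0.59 log units; beyond the scatter). Compound 3 is estimated at 2000 nM, within 500 nM to 8000 nM.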

Compound 3, half-maximal inhibitory concentration: 400 nM
Compound 3: the middle estimate sits 5.0-fold (0.70 log units) above what was measured; the whole stated range lies above it.
By their numbers in this assay, from the lowest: compounds 1 and 3 (each within the scatter of the next); then compound 2.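

Within the data shown here, on a carbonyl carbon whose other neighbour is an amide-type nitrogen, chloromethyl in place of vinyl gives a 20-fold lower number from compound 2 to compound 3 (1.29 log units; beyond the scatter), the first reading of this change on an otherwise unaltered structure. With chloromethyl held in place, ethoxycarbonyl in place of hydroxymethyl on an aromatic carbon shows no change at the digits printed from compound 1 to compound 3 (within the scatter). Nothing available bears on the reason for either result.

As far as these compounds go, it remains open how a methyl or a longer chain would read in place of chloromethyl on that carbonyl. Also open, from the compounds shown here alone, is how a carboxylic acid would read in place of ethoxycarbonyl, and whether hydroxymethyl and ethoxycarbonyl would match with vinyl on the carbonyl.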